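This account rests on a few compounds, and the source may have more. Where it says the series, first, only, none or still open, it means among the compounds named here.

In an ADME assay on L1210/0 cells (Mus musculus) for cytotoxicity, with a stated time of 48 h (a lower number here means a stronger inhibitor, a higher number a weaker inhibitor), compound 1 (`O=c1[nH]c(=O)n([C@H]2C[C@H](O)[C@@H](CO)O2)cc1C#CCCO`) gives > 200000 nM, which is a limit and not a number. Compound 2 (`CS(=O)(=O)Cc1cn([C@H]2C[C@H](O)[C@@H](CO)O2)c(=O)[nH]c1=O`) gives > 200000 nM, which is likewise a limit. All that the measurements show so far is the limit of > 200000 nM in this assay, at which 2 of the 2 values shown sit, so compound 1 has no readable place on the scale.

Compound 3 (`Cc1ccc(S(=O)(=O)OCCC#Cc2cn([C@H]3C[C@H](O)[C@@H](CO)O3)c(=O)[nH]c2=O)cc1`) has not yet been measured. It keeps the core and the alkyne chain of compound 1 and differs at one place: (4-methylphenyl)sulfonyl in place of hydrogen on an oxygen on a saturated carbon. The group enters on an oxygen on a saturated carbon, where it takes the place of a hydrogen.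

Among the measured compounds shown here, only one measured step bears on this, a step that the two limits leave unreadable from compound 1 to compound 2. That step replaces the whole 4-hydroxybut-1-yn-1-yl group, and with both ends at a limit it offers no size to carry over. The expectation therefore rests on the structural change alone and remains loose. A modest move towards stronger inhibition is expected, estimated as an at least 1.6-fold lower number from compound 1 to compound 3 (0.22 log units; that floor lies within the scatter). Another limit in this assay remains a real possibility. The estimate for compound 3 is 120000 nM, with an expected range from 30000 nM to 250000 nM.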

Compound 3, half-maximal inhibitory concentration: > 200000 nM
Compound 3: only a limit was reported (the forecaster's own chance of this, stated with the estimate: 45%); middle value at least 1.6-fold (0.22 log units) away from the limit.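

The step from compound 1 to compound 3 cannot be read, and neither can any other step among the compounds shown, because every value is a limit and not a number: the limit of > 200000 nM in this assay, at which 3 of the 3 values shown sit.

The compounds shown leave open where compound 1, compound 2 and compound 3 stand on the scale, and whether (4-methylphenyl)sulfonyl in place of hydrogen changes the read-out at all.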